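The source may hold more compounds than are shown below. What is called first, only, known or untested is meant among the compounds shown, and "the series" means these compounds.

Working notes on the series. In a physicochemical assay for lipophilicity, at pH 7.4 (on this read-out lower numbers stand for lower lipophilicity and higher numbers for higher lipophilicity), compound 1, `O=C(Nc1cccc(Cl)c1)c1cc(C(F)(F)F)ccc1OCc1ccc(F)cc1`, gives 8.7. Among the compounds with values here, compound 2, `O=C(Nc1ccnnc1)c1cc(N2CCC(F)CC2)ccc1OCc1ccccc1`, gives 5.1 in this assay and stands lowest of the two numbers so far; its nearest neighbour is compound 1, a gap beyond the scatter.

Compound 3, `O=C(Nc1ccnnc1)c1cc(N2CCC(CO)CC2)ccc1OCc1ccccc1`, has not been measured in this assay. Its structure differs from compound 2 in one place: hydroxymethyl in place of fluoro on a saturated ring carbon. Within the data shown here, no step between measured compounds covers a change of this kind.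

For compound 3 a step downward, beyond the scatter, is expected in this assay, amounting to a number 0.90 log units lower from compound 2 to compound 3 (beyond the scatter). Compound 3 is accordingly estimated at 4.2, with a range from 3.5 to 4.9.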

Compound 3, distribution coefficient: 3.5
For compound 3 the middle estimate is 0.70 log units above the measured one, within the range that was stated.
By their numbers in this assay, from the lowest: compound 3; then compound 2; then compound 1.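

In this assay, within the data shown here, the change from 4-fluoropiperidin-1-yl to 4-(hydroxymethyl)piperidin-1-yl gives a number 1.60 log units lower from compound 2 to compound 3 (beyond the scatter) as the first single-place step. This saturated ring carbon is therefore a place where one substituent change moves the read-out beyond the scatter. No measured evidence on hand accounts for the size of this step.

On these data alone, whether a simple methyl, a longer chain ending in hydroxyl, an amine or a carboxylic acid on this carbon would give a similar step remains open. The compounds shown also do not separate the contribution of the added carbon from that of the oxygen.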